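This account rests on a few compounds, and the source may have more. Where it says the series, first, only, none or still open, it means among the compounds named here.

Measured so far in an assay on CHO cells for displacement of a labelled ligand from adenosine receptor A1 (Homo sapiens), read by scintillation counting, with a stated time of 90 min; on this read-out lower numbers stand for stronger inhibition and higher numbers for weaker inhibition: compound 1 `N#Cc1c(N)nc(SCc2ccn[nH]2)c(C#N)c1-c1ccc(OCC2CC2)cc1` gives 552 nM. Compound 2 `N#Cc1c(N)nc(SCc2ncc[nH]2)c(C#N)c1-c1ccc(OCC2CC2)cc1` gives 235 nM. Compound 3 `N#Cc1c(N)nc(SCC2=NCCN2)c(C#N)c1-c1ccc(OCC2CC2)cc1` gives 483 nM, the second highest of the three numbers, within the scatter of compound 1 and beyond it only against compound 2.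

Compound 4 `N#Cc1c(N)nc(SCc2ncn[nH]2)c(C#N)c1-c1ccc(OCC2CC2)cc1` differs from compound 3 in that (a group of 5 heavy atoms (2 carbon, 3 nitrogen; one five-membered aromatic ring with 3 hetero atoms) in place of a group of 5 heavy atoms (3 carbon, 2 nitrogen; one five-membered non-aromatic ring with 2 hetero atoms), on a saturated chain carbon bound to a sulfur). For the measured compounds named here, two measured steps bear on this: both exchange an aromatic five-membered ring for the same non-aromatic ring at the same place, and they ran a 1.1-fold lower number from compound 1 to compound 3 (0.06 log units; within the scatter) and a 2.1-fold higher number from compound 2 to compound 3 (0.31 log units; beyond the scatter). The new ring is aromatic again, so a lower number or none beyond the scatter is expected, a 1.4-fold lower number from compound 3 to compound 4 (0.14 log units; within the scatter). Compound 4 is therefore estimated at 350 nM, within 150 nM to 800 nM.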

Compound 4, inhibition constant: 338 nM
Compound 4: middle estimate off by 1.0-fold (0.02 log units), on the high side; low and high end bracket the measured number.
By their numbers in this assay, from the lowest: compounds 2, 4, 3 and 1 (each within the scatter of the next, the first and the last beyond it).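

In this assay, the 1H-1,2,4-triazol-5-yl group on a saturated chain carbon bound to a sulfur stays within the scatter of each earlier ring (a 1.4-fold lower number from compound 3 to compound 4 (0.16 log units; within the scatter)) (a 1.4-fold higher number from compound 2 to compound 4 (0.16 log units; within the scatter)) (a 1.6-fold lower number from compound 1 to compound 4 (0.21 log units; within the scatter)). A five-membered aromatic ring with 3 hetero atoms is therefore accepted here about as well as the rings with 2, and compound 4 cannot separate them. On these data alone, whether an amine, a carboxylic acid or a longer chain in place of the ring would hold this level stays open. No measurement offers an explanation for these results.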